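The source may report more compounds than this note shows. Statements on the series, on what has been measured and on what is new or still open speak of the compounds shown alone.

Measured so far:
Compound 1, `CCn1c(C(=O)NCC(OC)OC)ccc1C(CC)(CC)c1ccc(OCC(=O)C(C)(C)C)c(C)c1`: in an assay on HL-60 cells for agonist activity at vitamin D3 receptor (Homo sapiens), read by microscopy, with a stated time of 96 h (on this read-out higher numbers stand for an effect only at larger amounts of compound and lower numbers for an effect already at smaller amounts), compound 1 gives 130 nM.
Compound 2, `CCn1c(C(=O)N(CCC#N)CCC#N)ccc1C(CC)(CC)c1ccc(OCC(=O)C(C)(C)C)c(C)c1`: in this assay compound 2 gives 870 nM.

Within the data shown here, compound 2 stands at the highest of the two numbers, and its only neighbour is compound 1, separated from it by a 6.7-fold higher number from compound 1 to compound 2 (0.83 log units; beyond the scatter). Compound 3, `CCn1c(C(=O)Nc2cccc(C(F)(F)F)c2)ccc1C(CC)(CC)c1ccc(OCC(=O)C(C)(C)C)c(C)c1`, differs from compound 2 on the carbonyl carbon whose other neighbour is aromatic carbon: a group of 11 heavy atoms (7 carbon, 1 nitrogen, 3 fluorine; one six-membered aromatic ring of carbon only) in place of a group of 9 heavy atoms (6 carbon, 3 nitrogen; no ring), on a carbonyl carbon. Among the measured compounds shown here, the single measured step at this carbonyl, the one from compound 1 to compound 2, was modest and went upward when the group with 1 hydrogen-bond donor was replaced by one with none; compound 3 brings back a group with 1 hydrogen-bond donor. A downward step of similar, modest size is therefore expected in this assay, because compound 1 gives 130 nM with such a group. Compound 3 is estimated at 300 nM, within 80 nM to 1500 nM. This expectation amounts to a 2.9-fold lower number from compound 2 to compound 3 (0.46 log units; beyond the scatter).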

Compound 3, half-maximal effective concentration: > 50000 nM
Compound 3 ended at the assay's limit; the forecaster's own chance of this, stated with the estimate: 10%; middle value at least 160-fold (2.22 log units) from the limit.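

Two groups that each carry 1 hydrogen-bond donor can end up very far apart at this carbonyl carbon: 3-(trifluoromethyl)phenyl in place of 2,2-dimethoxyethyl on the amide-type nitrogen gives an at least 380-fold higher number from compound 1 to compound 3 (2.58 log units; beyond the scatter). The change from the group without a donor points the same way, with an at least 57-fold higher number from compound 2 to compound 3 (1.75 log units; beyond the scatter), so the donor count alone does not track the numbers across these compounds. In this assay compound 3 gives > 50000 nM, which is a limit of the assay and not a number.

The compounds shown do not separate the aromatic ring from the trifluoromethyl group it carries, a comparison that an unsubstituted phenyl group on the same nitrogen would provide. As far as these compounds go, it also remains open how a short alkyl chain such as ethyl, or a carboxylic acid on that chain, would behave at this carbonyl carbon.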